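This account rests on a few compounds, and the source may have more. Where it says the series, first, only, none or still open, it means among the compounds named here.

Series notes. Within the data shown here, compound 1 `O=c1[nH]cnc2c1c(-c1ccoc1)cn2[C@@H]1O[C@H](CO)[C@@H](O)[C@H]1O` is the reference point; in a functional assay on HCT-116 cells (Homo sapiens), read by MTT assay, with a stated time of 72 h (on this read-out lower numbers stand for stronger inhibition and higher numbers for weaker inhibition), compound 1 gives 14800 nM, one of only two numbers measured so far, and the other compound sits within the scatter of it. Compound 2 `Nc1nc2c(c(-c3ccoc3)cn2[C@@H]2O[C@H](CO)[C@@H](O)[C@H]2O)c(=O)[nH]1` carries an amino group in place of a hydrogen on an aromatic carbon; in this assay compound 2 gives 17600 nM, and the step of a 1.2-fold higher number from compound 1 to compound 2 (0.08 log units; within the scatter) is within the scatter. Compound 3 `O=c1[nH]cnc2c1c(-c1cc3ccccc3o1)cn2[C@@H]1O[C@H](CO)[C@@H](O)[C@H]1O` is not yet measured. It differs from compound 1 by 1-benzofuran-2-yl in place of furan-3-yl on an aromatic carbon, the exchange sitting on an aromatic carbon of a five-membered aromatic ring with one nitrogen, part of a fused system of two rings. Among the measured compounds shown here, no measured step touches this position; the one step available concerns an amino group elsewhere and says nothing about swapping one ring group for another here. The expectation therefore rests on compound 1 alone: compound 3 is expected to stay near it, with a step of a 1.5-fold lower number from compound 1 to compound 3 (0.17 log units; within the scatter) of uncertain direction. The estimate for compound 3 in this assay is 10000 nM, with a range from 2000 nM to 50000 nM.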

Compound 3, half-maximal inhibitory concentration: > 20000 nM
Compound 3: a limit, no number; the forecaster's own chance of this, stated with the estimate: 10%; middle value at least 2.0-fold (0.30 log units) away from the limit.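

The value of compound 3 is a limit of the assay and not a number, and it is the only such reading among the compounds shown: the limit of > 20000 nM in this assay, at which 1 of the 3 values shown sits.

Putting 1-benzofuran-2-yl in place of furan-3-yl, on an aromatic carbon of a five-membered aromatic ring with 1 nitrogen, gives an at least 1.3-fold higher number from compound 1 to compound 3 (0.13 log units; that floor lies within the scatter) in this assay. Among these compounds, this is the first reading at this position, and it shows that the added six-membered aromatic ring of carbon only brings no stronger inhibition, while a true loss remains unproven, since the floor of the step lies within the scatter.

Still open, as far as these compounds go, is whether a simple amine or a phenyl ring on this carbon would read differently from furan-3-yl. From the compounds shown here alone, the true size of the step from furan-3-yl to 1-benzofuran-2-yl also stays open.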